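A few compounds are considered here, and "the series" means these few. Any claim that something is new, unique, unknown or untested is made for them only; others in the source may bear on it.

In a functional assay on HCT-15 cells (Homo sapiens) for inhibition, read by MTT assay, with a stated time of 72 h (a higher number here means a weaker inhibitor, a lower number a stronger inhibitor), compound 2 `CNCc1c(OC)cc(Oc2cccc(Nc3ccccc3)c2)cc1OC` gives 8930 nM. Among the three compounds measured so far, compound 2 stands second highest. Its nearest neighbour is compound 3 `COc1cc(Oc2cccc(Nc3ccccc3)c2)cc(OC)c1CN(C)C`, which in this assay gives 15600 nM; the step of a 1.7-fold higher number from compound 2 to compound 3 (0.24 log units; within the scatter) lies within the scatter, so the two cannot be ordered. Furthest from it is compound 1 `COc1ccc(CNCc2c(OC)cc(Oc3cccc(Nc4ccccc4)c3)cc2OC)cc1`, which in this assay gives 2650 nM; the step of a 3.4-fold higher number from compound 1 to compound 2 (0.53 log units; beyond the scatter) lies beyond the scatter.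

Compound 4 `COc1cc(Oc2cccc(Nc3ccccc3)c2)cc(OC)c1CNCc1ccc(Br)cc1` differs from compound 2 by 4-bromophenyl in place of hydrogen on a saturated chain carbon bound to an amine nitrogen. The step that bears on this change is a 3.4-fold higher number from compound 1 to compound 2 (0.53 log units; beyond the scatter), where hydrogen in place of 4-methoxyphenyl on the saturated chain carbon bound to the amine nitrogen raised the number. Going by the values given here, compound 4 puts an aryl group back on that carbon, with 4-bromophenyl rather than 4-methoxyphenyl, so a step of similar size in the opposite direction is expected, though no measured pair shows how bromine and methoxy compare at that position.

Compound 4 is therefore expected to give about 3000 nM, in a range from 1200 nM to 7500 nM. This expected shift corresponds to a step of a 3.0-fold lower number from compound 2 to compound 4 (0.47 log units; beyond the scatter).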

Compound 4, half-maximal inhibitory concentration: 5410 nM
Beside the measured number, compound 4's estimate is 1.8-fold (0.26 log units) below it; the range from low to high includes it.
By their numbers in this assay, from the lowest: compound 1; then compounds 4, 2 and 3 (each within the scatter of the next, the first and the last beyond it).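

In this assay, 4-bromophenyl on the saturated chain carbon bound to an amine nitrogen gives a 1.7-fold lower number from compound 2 to compound 4 (0.22 log units; within the scatter) and so does not separate compound 4 from compound 2, whereas 4-methoxyphenyl at that place had set compound 1 apart from compound 2. Bromo in place of methoxy on an aromatic carbon gives a 2.0-fold higher number from compound 1 to compound 4 (0.31 log units; beyond the scatter) as a modest step, which shows that the group carried on the ring counts here, not only the presence of the ring itself. Compound 4 still separates from the dimethylamino compound, with a 2.9-fold lower number from compound 3 to compound 4 (0.46 log units; beyond the scatter) as a step beyond the scatter.

Nothing available accounts for the difference between bromo and methoxy. From the compounds shown here alone, it remains open whether hydroxy or trifluoromethyl in place of methoxy, or an unsubstituted benzyl or a phenethyl group on the amine nitrogen, would fall nearer compound 1 or compound 2.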